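Changing the Group on the Oxygen of Compound 2

The source may report more compounds than this note shows. Statements on the series, on what has been measured and on what is new or still open speak of the compounds shown alone.

In an ADME assay on microsomes from liver (Mus musculus) for metabolic stability, using NADPH, with a stated time of 60 min, in the presence of a further agent that is not named here (a lower number here means slower removal, a higher number faster removal of the compound), compound 1 (`O=C(O)CCCCOc1ccc([C@H]2CC[C@]3(CC2)OOC2(O3)C3CC4CC(C3)CC2C4)cc1`) gives 13 mL.min-1.g-1 here, while compound 2 (`CC(C)(Oc1ccc([C@H]2CC[C@]3(CC2)OOC2(O3)C3CC4CC(C3)CC2C4)cc1)C(=O)O`) gives 7 mL.min-1.g-1 here, the two lying within the scatter of each other. Compound 3 (`CS(=O)(=O)NC(=O)COc1ccc([C@H]2CC[C@]3(CC2)OOC2(O3)C3CC4CC(C3)CC2C4)cc1`) carries ((methylsulfonyl)carbamoyl)methyl in place of 1-carboxy-1-methylethyl on an oxygen on an aromatic ring. Within the data shown here, the one measured step at this place is a 1.9-fold lower number from compound 1 to compound 2 (0.27 log units; within the scatter) and it involves a different group, with no measurement yet of the entering one. The expected change is a 1.4-fold higher number from compound 2 to compound 3 (0.15 log units; within the scatter) and nothing beyond the scatter is foreseen. Compound 3 is expected at 10 mL.min-1.g-1 in this assay with an estimated range of 4 mL.min-1.g-1 to 25 mL.min-1.g-1 here.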

Compound 3, intrinsic clearance in microsomes in the Mus musculus assay: 12 mL.min-1.g-1
Compound 3: middle estimate off by 1.2-fold (0.08 log units), on the low side; low and high end bracket the measured number.
By their numbers in the Mus musculus assay, from the lowest: compounds 2, 3 and 1 (each within the scatter of the next).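

In the Mus musculus assay, compound 1 gives 13 mL.min-1.g-1, compound 2 gives 7 mL.min-1.g-1 and compound 3 gives 12 mL.min-1.g-1. In the Mus musculus assay, ((methylsulfonyl)carbamoyl)methyl on this oxygen proves interchangeable with 1-carboxy-1-methylethyl (a 1.7-fold higher number from compound 2 to compound 3 (0.23 log units; within the scatter)), and (methylsulfonyl)carbamoyl proves interchangeable with 3-carboxypropyl on a saturated chain carbon bound to an oxygen on an aromatic ring (a 1.1-fold lower number from compound 1 to compound 3 (0.03 log units; within the scatter)). In a physicochemical assay for lipophilicity, read by HPLC, at pH 7.4 (on this read-out lower numbers stand for lower lipophilicity and higher numbers for higher lipophilicity), compound 2 gives 3.1 and compound 3 gives 3, and the change from 1-carboxy-1-methylethyl also stays within the scatter (a number 0.10 log units lower from compound 2 to compound 3 (within the scatter)). Nothing available gives a reason for these results. As far as these compounds go, whether a tetrazole or an amine on this oxygen would move either read-out beyond the scatter remains open. So does the outcome of a longer chain carrying the (methylsulfonyl)carbamoyl group.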